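The compounds below may be only part of what the source reports. "The series", "measured", "known", "first", "only" and "open" are said of these compounds alone.

Compound 1 `Cc1ccc(C2=NN(c3nc(-c4ccc(F)cc4)cs3)C(c3ccc(F)cc3)C2)s1` and compound 2 `Cc1ccc(C2=NN(c3nc(-c4ccc(C#N)cc4)cs3)C(c3ccc(F)cc3)C2)s1` share one core and differ only at a single aromatic carbon. In an ADME assay on NIH3T3 cells (Mus musculus) for cytotoxicity, read by XTT assay, with a stated time of 24 h (on this read-out higher numbers stand for weaker inhibition and lower numbers for stronger inhibition), compound 1 gives a value that is a limit of the assay, > 500 ug/mL. In this assay compound 2 gives 250 ug/mL. For the measured compounds named here, the step of an at least 2.0-fold lower number from compound 1 to compound 2 (0.30 log units; that floor lies within the scatter) is the only measured step, and it rests on (the limit of > 500 ug/mL in this assay, at which 1 of the 2 values shown sits), so its true size is not fixed. Going by the values given here, compound 2 therefore stands as the one compound with a number in this assay, while the other value is a limit.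

Compound 3 `Cc1ccc(C2=NN(c3nc(-c4ccc(Cl)cc4)cs3)C(c3ccc(F)cc3)C2)s1` differs from compound 2 by chloro in place of cyano on an aromatic carbon. Among the compounds with values here, the one measured step bears on it only loosely, since it swapped fluoro for cyano, not cyano for chloro, and its floor lies within the scatter. With a halogen entering, as in compound 1 with > 500 ug/mL, the number is expected to move back up in this assay, by about a 1.6-fold higher number from compound 2 to compound 3 (0.20 log units; within the scatter), with a real chance that only a limit is reported. Compound 3 is thus expected to give about 400 ug/mL, between 150 ug/mL and 1000 ug/mL.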

Compound 3, half-maximal inhibitory concentration: > 500 ug/mL
Compound 3: a limit, no number; the forecaster's own chance of this, stated with the estimate: 50%; middle value at least 1.2-fold (0.09 log units) from the limit.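

The change from 4-cyanophenyl to 4-chlorophenyl gives an at least 2.0-fold higher number from compound 2 to compound 3 (0.30 log units; that floor lies within the scatter). A second halogen at this position, chloro after the fluoro of compound 1, has now ended at the limit of this assay, so compound 2 with its nitrile is the only one of the three with an actual number, although the floor of this step does not clear the usual scatter. The step from compound 1 to compound 3 cannot be read, so fluoro and chloro cannot be ordered against each other, and the true size of each step from the nitrile remains unfixed: the limit of > 500 ug/mL in this assay, at which 2 of the 3 values shown sit.

From the compounds shown here alone, whether a measurable number at this aromatic carbon is special to the nitrile remains open, since an amine, a carboxylic acid or a methoxy group in the same place could either give a number or end at the limit. Also open, going by these compounds, is what actual numbers compound 1 and compound 3 would give if the assay reached further, and whether they would then differ from each other.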